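Replacing 2,4-dimethylphenyl with naphthalen-1-yl in compound 1

The compounds below may be only part of what the source reports. "The series", "measured", "known", "first", "only" and "open" are said of these compounds alone.

Among the compounds with values here, in an ADME assay on microsomes from liver (Mus musculus) for metabolic stability, read by LC-MS, with a stated time of 40 min (a higher number here means that the compound lasts longer, a lower number that the compound disappears faster), compound 1 (`Cc1ccc(C(=O)N(CC(=O)NCc2ccccc2)Cc2ccc(C(=O)NO)cc2)c(C)c1`) gives 0.747 h, the second highest of the three numbers measured so far. Compound 2 (`CNC(=O)CN(Cc1ccc(C(=O)NO)cc1)C(=O)c1ccc(C(C)C)cc1`) gives 4.52 h, and compound 3 (`Cc1ccc(C(=O)N(CC(=O)NC2CCCCC2)Cc2ccc(C(=O)NO)cc2)c(C)c1`) gives 0.298 h.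

The next molecule, compound 4 (`O=C(CN(Cc1ccc(C(=O)NO)cc1)C(=O)c1cccc2ccccc12)NCc1ccccc1`), keeps the core of compound 1 and exchanges a single group: naphthalen-1-yl in place of 2,4-dimethylphenyl on a carbonyl carbon. Here naphthalen-1-yl takes the place of 2,4-dimethylphenyl on a carbonyl carbon.

Within the data shown here, the only measured step available is modest: a 2.5-fold lower number from compound 1 to compound 3 (0.40 log units; beyond the scatter), with cyclohexyl in place of benzyl on an amide-type nitrogen. That change sits at a different place, so it offers little guidance here. Compound 2 differs from compound 1 in more than one place, so its number does not isolate the effect of the carbonyl substituent. Among the measured compounds shown here, with no measured step at this place, no step beyond the scatter is expected in this assay, and the direction stays open.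

The expected change is a 1.1-fold lower number from compound 1 to compound 4 (0.03 log units; within the scatter). For compound 4 the estimated half-life is 0.7 h, with an expected range from 0.25 h to 2 h.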

Compound 4, half-life: 0.322 h
Compound 4: middle estimate off by 2.2-fold (0.34 log units), on the high side; the range from low to high includes it.
By their numbers in this assay, from the lowest: compounds 3 and 4 (each within the scatter of the next); then compound 1; then compound 2.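

In this assay, the step at this place is a 2.3-fold lower number from compound 1 to compound 4 (0.37 log units; beyond the scatter), with naphthalen-1-yl in place of 2,4-dimethylphenyl on a carbonyl carbon. Within the data shown here, this is the first measured step at this carbonyl carbon, and it shows that the group held there can shift the half-life beyond the scatter, as a 2.5-fold lower number from compound 1 to compound 3 (0.40 log units; beyond the scatter) did at the amide-type nitrogen. No measurement shown here speaks to the cause of this drop.

A single replacement cannot separate the gain of a second aromatic ring from the loss of the two methyl groups as the source of the lower number. Going by these compounds, how an unsubstituted phenyl ring or a pyridine ring on the same carbonyl carbon would behave, with the rest of compound 1 unchanged, also stays open.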